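Working notes: amide-to-ether change on the fused bicyclic core

The compounds below may be only part of what the source reports. "The series", "measured", "known", "first", "only" and "open" are said of these compounds alone.

Measured compounds:
- compound 1, `Cc1nn(-c2ncnc3nc[nH]c23)c2c1C(C(=O)NCc1ccc(F)cc1)CC(=O)N2`, 1220 nM in a functional assay on HEK293 cells for agonist activity at G-protein coupled receptor 39 (Homo sapiens), read by scintillation proximity assay and inositol phosphate accumulation, with a stated time of 75 min; a higher number here means that more compound is needed for the effect, a lower number that less compound is needed
- compound 2, `Cc1nn(-c2ncnc3nc[nH]c23)c2c1C(C(=O)NCc1ccccc1)CC(=O)N2`, 2930 nM
- compound 3, `Cc1cc(C)nc(-n2nc(C)c3c2NC(=O)CC3c2ccc(COc3cccc(Cl)c3)cc2)n1`, 3000 nM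

Compound 2 stands second highest of the three numbers; compound 3 sits within the scatter of it, while compound 1 lies beyond the scatter on the lower side.

Compound 4, `Cc1nn(-c2ncnc3nc[nH]c23)c2c1C(OCc1ccc(F)cc1)CC(=O)N2`, is not yet measured. It differs from compound 2 by (4-fluorobenzyl)oxy in place of benzylcarbamoyl on a saturated ring carbon. Two things change at once: the fluoro returns, and the benzylcarbamoyl linkage becomes an ether.

For the measured compounds named here, only one measured step bears on this: a 2.4-fold higher number from compound 1 to compound 2 (0.38 log units; beyond the scatter). Read in the opposite direction it suggests that the fluoro alone would lower the number by a modest amount. Going by the values given here, no measured pair shows what replacing the carbamoyl with an oxygen link does, so that part of the change is unanchored.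

On the fluoro step alone the expected number is lower; the unanchored ether change widens the range. Compound 4 is therefore estimated at 2000 nM, range 400 nM to 10000 nM, an expected step of a 1.5-fold lower number from compound 2 to compound 4 (0.17 log units; within the scatter).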

Compound 4, half-maximal effective concentration: 126 nM
For compound 4 the middle estimate is 16-fold (1.20 log units) above the measured one, and the stated range ends above it.
By their numbers in this assay, from the lowest: compound 4; then compound 1; then compounds 2 and 3 (each within the scatter of the next).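

On the saturated ring carbon, (4-fluorobenzyl)oxy in place of benzylcarbamoyl gives a 23-fold lower number from compound 2 to compound 4 (1.37 log units; beyond the scatter) in this assay and this is much larger in size than the fluoro step, a 2.4-fold higher number from compound 1 to compound 2 (0.38 log units; beyond the scatter). With the fluoro present in both, compound 1 gives 1220 nM and compound 4 gives 126 nM, so most of the drop goes with the ether in place of the carbamoyl link, and the donor of benzylcarbamoyl is not needed for activity at this position. No independent data explain why the ether link gives this result.

As far as these compounds go, it remains open whether the fluoro step seen with the amide carries over to the ether. Also open, from the compounds shown here alone, is how an amine link or a longer chain between this carbon and the aromatic ring would compare with the benzyl ether.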